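The compounds below may be only part of what the source reports. "The series", "measured", "known", "first", "only" and "open" are said of these compounds alone.

Working notes on the series. In a functional assay on RAW264.7 cells (Mus musculus) for inhibition, read by ELISA, with a stated time of 24 h (on this read-out lower numbers stand for an effect already at smaller amounts and higher numbers for an effect only at larger amounts of compound), compound 1 `CC/C=C\C[C@H]1C(=O)C=C[C@H]1CC(=O)OCC` gives 20000 nM, compound 2 `CC/C=C\C[C@H]1C(=O)C=C[C@H]1CC(=O)OCc1ccccc1` gives 20000 nM and compound 3 `CC/C=C\C[C@H]1C(=O)C=C[C@H]1CC(=O)OC(C)C` gives 20000 nM, so compound 3 stands level with the other two. Next comes compound 4 `CC/C=C\C[C@H]1C(=O)C=C[C@H]1CC(=O)OC(C)c1ccccc1`, with the difference phenyl in place of methyl on a saturated chain carbon bound to an oxygen next to a carbonyl group and a saturated chain carbon. The closest measured exchange, also phenyl in place of methyl, shows no change at the digits printed from compound 1 to compound 2 (within the scatter). The other two steps show no change at the digits printed from compound 1 to compound 3 (within the scatter) and no change at the digits printed from compound 2 to compound 3 (within the scatter). No step beyond the scatter is therefore expected in this assay. The expected step is no change at the digits printed from compound 3 to compound 4 (within the scatter). Compound 4 is estimated at 20000 nM, with an expected range of 10000 nM to 40000 nM.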

Compound 4, half-maximal effective concentration: 18000 nM
The estimate for compound 4 lay 1.1-fold (0.05 log units) above the measured number, within the range that was stated.
By their numbers in this assay, from the lowest: compounds 4, 1, 2 and 3 (each within the scatter of the next).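

In this assay, within the data shown here, a saturated chain carbon bound to an oxygen next to a carbonyl group now carries both methyl and phenyl, and no step leaves the scatter: a 1.1-fold lower number from compound 3 to compound 4 (0.05 log units; within the scatter), a 1.1-fold lower number from compound 2 to compound 4 (0.05 log units; within the scatter) and a 1.1-fold lower number from compound 1 to compound 4 (0.05 log units; within the scatter). Phenyl in place of methyl reads the same on a second core: the same change on two cores in this assay, no change at the digits printed (within the scatter) from compound 1 to compound 2 and a 1.1-fold lower number (0.05 log units; within the scatter) from compound 3 to compound 4, 1.1-fold (0.05 log units) apart, within the scatter of two such steps Methyl in place of hydrogen also reads the same with phenyl present: the same change on two cores in this assay, no change at the digits printed (within the scatter) from compound 1 to compound 3 and a 1.1-fold lower number (0.05 log units; within the scatter) from compound 2 to compound 4, 1.1-fold (0.05 log units) apart, within the scatter of two such steps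

From the compounds shown here alone, whether a carboxylic acid, an amide or a longer chain here would give a step beyond the scatter remains open. So does the effect of any change on the shared core.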